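Urea series: swapping methylsulfanyl for amino

This account rests on a few compounds, and the source may have more. Where it says the series, first, only, none or still open, it means among the compounds named here.

Three ureas have been measured in a physicochemical assay for solubility, at pH 7.4; a higher number here means a more soluble compound, a lower number a less soluble compound. Compound 1 `Cc1cc(NC(=O)Nc2ccccc2F)c2ccccc2n1` gives 3800 nM, compound 2 `Cc1cc(NC(=O)Nc2ccc(F)cc2)c2ccccc2n1` gives 3700 nM, and compound 3 `CSc1ccccc1NC(=O)Nc1cc(C)nc2ccccc12` gives 21000 nM, the highest of the three. Among the measured compounds shown here, the step of a 1.0-fold lower number from compound 1 to compound 2 (0.01 log units; within the scatter) was flat, whereas a 5.5-fold higher number from compound 1 to compound 3 (0.74 log units; beyond the scatter) was the only step beyond the scatter. Compound 4 `Cc1cc(NC(=O)Nc2ccccc2N)c2ccccc2n1` differs from compound 3 by amino in place of methylsulfanyl on an aromatic carbon. For the measured compounds named here, no measured step covers this exact exchange; the nearest evidence is that methylsulfanyl lifted the number over fluoro in compound 3, so removing it may give some of that back. A modest downward step a 2.1-fold lower number from compound 3 to compound 4 (0.32 log units; beyond the scatter) is therefore expected, placing compound 4 at an estimated 10000 nM, within the range 3000 nM to 40000 nM.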

Compound 4, solubility: 51800 nM
Compound 4: middle estimate off by 5.2-fold (0.71 log units), on the low side, and the stated range ends below it.
By their numbers in this assay, from the lowest: compounds 2 and 1 (each within the scatter of the next); then compound 3; then compound 4.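

Among the compounds shown here, on an aromatic carbon ortho to a large group, amino gives the highest number so far in this assay: replacing methylsulfanyl gives a 2.5-fold higher number from compound 3 to compound 4 (0.39 log units; beyond the scatter), and replacing fluoro gives a 14-fold higher number from compound 1 to compound 4 (1.13 log units; beyond the scatter). Methylsulfanyl is therefore not the only group here to lift the number over fluoro, and 2-aminophenyl in place of 4-fluorophenyl on the amide-type nitrogen gives a 14-fold higher number from compound 2 to compound 4 (1.15 log units; beyond the scatter). No measurement shown here explains these rises. From the compounds shown here alone, whether a methylamino or hydroxyl group at this place would match amino remains open, as does whether amino would act alike elsewhere on this ring.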